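Moving a Halogen on the Benzamide Ring

This account rests on a few compounds, and the source may have more. Where it says the series, first, only, none or still open, it means among the compounds named here.

Compound 2 `CC1(C)CC12NC(=O)N(NC(=O)c1ccccc1Cl)C2=O` was tested in a functional assay on the whole organism (Hindlimb) for inhibition, with Mus musculus as the target, with a stated time of 0.5 h (a lower number here means that less compound is needed, a higher number that more compound is needed for the effect), where compound 2 needed 300 mg/kg. Within the data shown here, of the two numbers known so far, this is the higher one; the nearer neighbour, compound 1 `Cc1ccc(C(=O)NN2C(=O)NC3(CC3(C)C)C2=O)cc1`, needed 100 mg/kg. Among the measured compounds shown here, the one measured step, a 3.0-fold higher number from compound 1 to compound 2 (0.48 log units; beyond the scatter), runs in the opposite direction to the change now considered. Compound 3 `CC1(C)CC12NC(=O)N(NC(=O)c1ccc(Br)cc1)C2=O` is made from compound 2 by the change (4-bromophenyl in place of 2-chlorophenyl on a carbonyl carbon). Since a 4-substituted phenyl gave the lower number in compound 1, and the 2-chlorophenyl gave the higher one in compound 2, a return to a 4-substituted phenyl is expected to bring the number back down, though bromine in place of methyl adds uncertainty. The expected step is a 3.0-fold lower number from compound 2 to compound 3 (0.48 log units; beyond the scatter). Compound 3 is therefore estimated at 100 mg/kg, with a likely range from 50 mg/kg to 300 mg/kg.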

Compound 3, minimum effective dose: 300 mg/kg
Compound 3: the middle estimate sits 3.0-fold (0.48 log units) below what was measured; the range from low to high includes it.
By their numbers in this assay, from the lowest: compound 1; then compounds 2 and 3 (each within the scatter of the next).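

In this assay, replacing 2-chlorophenyl with 4-bromophenyl leaves the number unmoved (no change at the digits printed from compound 2 to compound 3 (within the scatter)), so a 4-substituted phenyl does not by itself give a lower number. Bromo in place of methyl on an aromatic carbon gives a clear rise (a 3.0-fold higher number from compound 1 to compound 3 (0.48 log units; beyond the scatter)), which shows that the identity of the group matters, and compound 1 remains the only one of the three that needs a lower dose. No supporting measurement accounts for this difference between methyl and bromo.

Both the halogen and its place on the ring change between compound 2 and compound 3, so the flat result cannot show how each change acts alone. On these data alone, it also remains open how the number would respond to a larger alkyl chain, an amine or a carboxylic acid on the phenyl ring.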